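Acid to Methylamide on a Shared Core

A few compounds are considered here, and "the series" means these few. Any claim that something is new, unique, unknown or untested is made for them only; others in the source may bear on it.

Compound 1, `Cn1ccc2cc(-c3cnccc3/C=C/C(=O)O)ccc21`, was examined in a functional assay on MCF7 cells (Homo sapiens) for inhibition, read by sulforhodamine B assay, with a stated time of 72 h; on this read-out higher numbers stand for weaker inhibition of growth and lower numbers for stronger inhibition of growth. In this assay compound 1 gives only a limit of the assay, > 10000 nM, and not a number. The other measured compound, compound 2, `CNC(=O)/C=C/c1ccncc1-c1ccc2c(cnn2C)c1`, carries a methylcarbamoyl end group on a different core. In this assay compound 2 likewise gives a limit of the assay, > 10000 nM. Among the measured compounds shown here, both measured values sit at the limit of > 10000 nM in this assay, at which 2 of the 2 values shown sit, and compound 1 thus stands level with the only other measured compound, with neither showing growth inhibition within the tested range. Compound 3, `CNC(=O)/C=C/c1ccncc1-c1ccc2c(ccn2C)c1`, has not yet been measured. It differs from compound 1 by methylamino in place of hydroxy on a carbonyl carbon. For the measured compounds named here, no step between measured compounds is available to size this change. Compound 3 is expected to show no step beyond the scatter, with an estimated step that the limit leaves unreadable from compound 1 to compound 3. Compound 3 is accordingly estimated at 15000 nM in this assay, between 5000 nM and 50000 nM, and most likely again reported only as a limit.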

Compound 3, concentration for 50% growth inhibition: 7120 nM
Compound 3: middle estimate off by 2.1-fold (0.32 log units), on the high side; the measured number falls inside the stated range.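

In this assay compound 3 is the only one of the compounds shown that gives a number and not a limit, with 7120 nM. On the shared core, methylamino in place of hydroxy on a carbonyl carbon can so far be sized only as an at least 1.4-fold lower number from compound 1 to compound 3 (0.14 log units; that floor lies within the scatter). That step is a floor and not a measured size, because compound 1 gives only a limit: the limit of > 10000 nM in this assay, at which 2 of the 3 values shown sit.

Going by these compounds, whether the true step from carboxy to methylcarbamoyl goes beyond the scatter stays open, as compound 1 has no number in this read-out. On these data alone, how an unsubstituted amino group, a dimethylamino group or a methoxy group would read on the same carbonyl carbon also stays open.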